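Bromo for methyl on the indole ring of a diterpenoid core

This account rests on a few compounds, and the source may have more. Where it says the series, first, only, none or still open, it means among the compounds named here.

The measured compounds are compound 1 `COC(=O)[C@@]1(C)CCC=C2[C@@H]1CC[C@@H](C)[C@]2(C)Cc1c(C)[nH]c2ccc(C)cc12`, compound 2 `COC(=O)[C@@]1(C)CCC=C2[C@@H]1CC[C@@H](C)[C@]2(C)Cc1c(C)[nH]c2ccc(Br)cc12` and compound 3 `COC(=O)[C@@]1(C)CCC=C2[C@@H]1CC[C@@H](C)[C@]2(C)Cc1c(C)[nH]c2c(C)cccc12`. In a functional assay on HBL-100 cells (Homo sapiens) for inhibition, read by sulforhodamine B assay, with a stated time of 48 h (a lower number here means a stronger inhibitor of growth, a higher number a weaker inhibitor of growth), compound 1 gives 25000 nM, compound 2 gives 15000 nM and compound 3 gives 16000 nM.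

Compound 2 differs from compound 1 by bromo in place of methyl on an aromatic carbon, and the step measured was a 1.7-fold lower number from compound 1 to compound 2 (0.22 log units; within the scatter). Compound 3 has the same atoms as compound 1 joined differently; the difference between the two cores is not broken down here. The unmeasured compound 4 `COC(=O)[C@@]1(C)CCC=C2[C@@H]1CC[C@@H](C)[C@]2(C)Cc1c(C)[nH]c2c(Br)cccc12` differs from compound 3 by bromo in place of methyl on an aromatic carbon, the same kind of change as that from compound 1 to compound 2, though at a place that is ortho to a fused ring and meta to a fused ring rather than meta and para. Compound 4 is expected to show a step of about a 1.3-fold lower number from compound 3 to compound 4 (0.12 log units; within the scatter), because a 1.7-fold lower number from compound 1 to compound 2 (0.22 log units; within the scatter) stayed within the scatter. Compound 4 is thus estimated at 12000 nM, between 5000 nM and 30000 nM.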

Compound 4, concentration for 50% growth inhibition: 27000 nM
Compound 4: middle estimate off by 2.3-fold (0.35 log units), on the low side, within the range that was stated.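

In this assay, bromo in place of methyl on an aromatic carbon gives a 1.7-fold higher number from compound 3 to compound 4 (0.23 log units; within the scatter). Set beside the earlier step, this one runs in the opposite direction, and the gap between the two exceeds what two such steps would scatter: the same change on two cores in this assay, a 1.7-fold lower number (0.22 log units; within the scatter) from compound 1 to compound 2 and a 1.7-fold higher number (0.23 log units; within the scatter) from compound 3 to compound 4, 2.8-fold (0.45 log units) apart, beyond the scatter of two such steps. This shows that the step did not carry over unchanged from one core to the other, but each step alone stays within the scatter, so it does not show that bromo strengthens or weakens growth inhibition on either core, and a single pair per core cannot say what sets the two apart.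

The compounds shown leave open whether other groups on this ring, such as a methoxy, a nitrile or an amine, would give steps beyond the scatter. They also leave open what a carboxylic acid in place of the methyl ester would do.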